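A few compounds are considered here, and "the series" means these few. Any claim that something is new, unique, unknown or untested is made for them only; others in the source may bear on it.

Measured so far in a functional assay on HT-29 cells (Homo sapiens) for cytotoxicity, read by MTT assay, with a stated time of 72 h; on this read-out higher numbers stand for weaker inhibition and lower numbers for stronger inhibition:

Compound 1 `COc1ccc(/C=C/C(=O)Nc2cc(C(=O)c3cc(OC)c(OC)c(OC)c3)ccc2OC)cc1` gives 5010 nM.
Compound 2 `C#CCOc1cccc(/C=C/C(=O)Nc2cc(C(=O)c3cc(OC)c(OC)c(OC)c3)ccc2OC)c1` gives 7400 nM.
Compound 3 `COc1ccc(C(=O)c2cc(OC)c(OC)c(OC)c2)cc1NC(=O)/C=C/c1ccc(C(F)(F)F)cc1` gives 1600 nM.

Compound 3 stands lowest of the three, and both of its gaps lie beyond the scatter: the difference is a 3.1-fold lower number from compound 1 to compound 3 (0.50 log units; beyond the scatter) and a 4.6-fold lower number from compound 2 to compound 3 (0.67 log units; beyond the scatter). The step from compound 1 to compound 2, by contrast, is a 1.5-fold higher number from compound 1 to compound 2 (0.17 log units; within the scatter), so those two cannot be ranked against each other.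

Compound 4 `COc1cc(/C=C/C(=O)Nc2cc(C(=O)c3cc(OC)c(OC)c(OC)c3)ccc2OC)ccc1F` differs from compound 3 only at the far end of the chain: 4-fluoro-3-methoxyphenyl in place of 4-(trifluoromethyl)phenyl on a double-bonded chain carbon bound to a double-bonded chain carbon. Among the measured compounds shown here, the step that bears most directly on this change is the one from compound 1 to compound 3, in which a methoxy on the aromatic ring gave way to trifluoromethyl and the number fell by a 3.1-fold lower number from compound 1 to compound 3 (0.50 log units; beyond the scatter). Compound 4 moves back toward a methoxy-bearing ring, though with the methoxy in a different position and with a fluorine added, so the data give only partial guidance. The expectation is a modest rise in this assay, roughly undoing part of the earlier gain: a 2.2-fold higher number from compound 3 to compound 4 (0.34 log units; beyond the scatter). On that basis compound 4 is estimated at 3500 nM, within a range of 1500 nM to 8000 nM.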

Compound 4, half-maximal inhibitory concentration: 7700 nM
Compound 4: middle estimate off by 2.2-fold (0.34 log units), on the low side, and the stated range covers the measured number.
By their numbers in this assay, from the lowest: compound 3; then compounds 1, 2 and 4 (each within the scatter of the next).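

In this assay the new ring does not keep the low number of compound 3: there is a 4.8-fold higher number from compound 3 to compound 4 (0.68 log units; beyond the scatter) when 4-(trifluoromethyl)phenyl gives way to 4-fluoro-3-methoxyphenyl on the double-bonded chain carbon, so a fluorine on a ring that also carries methoxy does not reproduce what the trifluoromethyl ring gives. The other two steps, a 1.5-fold higher number from compound 1 to compound 4 (0.19 log units; within the scatter) and a 1.0-fold higher number from compound 2 to compound 4 (0.02 log units; within the scatter) are both within the scatter, so 4-methoxyphenyl, 3-(propargyloxy)phenyl and 4-fluoro-3-methoxyphenyl cannot be ranked against each other, and among these four compounds only the 4-(trifluoromethyl)phenyl ring stands apart. No measurement offered here explains that gap.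

As far as these compounds go, what remains open is whether the trifluoromethyl group itself sets compound 3 apart, which a plain 4-fluorophenyl ring or a ring with trifluoromethyl at another place could help to test. It is also unknown how a ring carrying an amine, a carboxylic acid or a nitrile would behave at this end of the chain, so the three oxygen-bearing rings and one trifluoromethyl ring give only a narrow view of this position.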